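A few compounds are considered here, and "the series" means these few. Any claim that something is new, unique, unknown or untested is made for them only; others in the source may bear on it.

Measured so far in a functional assay on MCF7 cells (Homo sapiens) for antiproliferative activity, read by MTT assay, with a stated time of 48 h; a lower number here means a stronger inhibitor, a higher number a weaker inhibitor:
compound 1 `O=C(Nc1cccc(/C=C/C(=O)c2nc3ccccc3[nH]2)c1)c1ccccc1` gives 11200 nM
compound 2 `O=C(/C=C/c1cccc(NC(=O)c2ccccc2Br)c1)c1nc2ccccc2[nH]1` gives 4520 nM
compound 3 `Cc1ccc(C(=O)Nc2cccc(/C=C/C(=O)c3nc4ccccc4[nH]3)c2)cc1` gives 9690 nM

Among these three numbers compound 3 stands second highest. Its nearest neighbour is compound 1, and the gap between them, a 1.2-fold lower number from compound 1 to compound 3 (0.06 log units; within the scatter), is within the scatter. Within the data shown here, the only step that sets compound 3 apart is a 2.1-fold higher number from compound 2 to compound 3 (0.33 log units; beyond the scatter), a modest difference, and the matching a 2.5-fold lower number from compound 1 to compound 2 (0.39 log units; beyond the scatter) shows the same modest size.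

Compound 4 `Cc1ccccc1S(=O)(=O)Nc1cccc(/C=C/C(=O)c2nc3ccccc3[nH]2)c1` is the next compound. It differs from compound 3 by (2-methylphenyl)sulfonyl in place of (4-methylphenyl)carbonyl on a nitrogen on an aromatic ring. Among the measured compounds shown here, no measured pair here exchanges a carbonyl for a sulfonyl on that nitrogen, so nothing bears on this change directly. What the measured steps do show is that a methyl on the aromatic ring, a 1.2-fold lower number from compound 1 to compound 3 (0.06 log units; within the scatter), leaves this assay unchanged, while the one substituent placed differently on that ring, a 2.5-fold lower number from compound 1 to compound 2 (0.39 log units; beyond the scatter), moves it only modestly. On that basis no step beyond the scatter is expected, and compound 4 is estimated at 8000 nM, with a range from 3000 nM to 25000 nM. The step this estimate implies, a 1.2-fold lower number from compound 3 to compound 4 (0.08 log units; within the scatter), is expected to be small.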

Compound 4, half-maximal inhibitory concentration: 4130 nM
Compound 4: the middle estimate sits 1.9-fold (0.29 log units) above what was measured; the range from low to high includes it.
By their numbers in this assay, from the lowest: compounds 4 and 2 (each within the scatter of the next); then compounds 3 and 1 (each within the scatter of the next).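

In this assay, the nitrogen on the aromatic ring proves to tolerate a sulfonyl as well as a carbonyl: placing (2-methylphenyl)sulfonyl there instead of (4-methylphenyl)carbonyl gives a 2.3-fold lower number from compound 3 to compound 4 (0.37 log units; beyond the scatter), and placing it there instead of benzoyl gives a 2.7-fold lower number from compound 1 to compound 4 (0.43 log units; beyond the scatter), both modest steps. Against the bromo-bearing amide the exchange gives a 1.1-fold lower number from compound 2 to compound 4 (0.04 log units; within the scatter), so (2-methylphenyl)sulfonyl and (2-bromophenyl)carbonyl cannot be told apart at this nitrogen, and the two groups are the only ones shown that stand beyond the scatter from benzoyl. Nothing presented here offers an explanation for these steps.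

Each of these steps changes the carbonyl to a sulfonyl and alters the ring substituent at the same time, so the share of the sulfonyl and the share of the methyl's place cannot be separated; (4-methylphenyl)sulfonyl or unsubstituted phenylsulfonyl on the same nitrogen would part them. The compounds shown also leave open how this nitrogen would respond to a group without an aromatic ring, such as a longer alkyl chain on the sulfonyl, or to an amine or a carboxylic acid on the aromatic ring.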